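A few compounds are considered here, and "the series" means these few. Any claim that something is new, unique, unknown or untested is made for them only; others in the source may bear on it.

Measured compounds:
- compound 1 `Cc1c(C(=O)c2ccc(Oc3ccccc3)cc2)oc2cc(-c3ccccc3)cc(O)c12`: > 4 ug/mL in a functional assay on WI-38 VA13 cells (Homo sapiens) for cytotoxicity; on this read-out lower numbers stand for an effect already at smaller amounts and higher numbers for an effect only at larger amounts of compound
- compound 2 `Cc1c(C(=O)c2cccc(OC(C)C)c2)oc2cc(-c3ccccc3)cc(O)c12`: 0.35 ug/mL in this assay
- compound 3 `COc1ccc(C(=O)c2oc3cc(-c4ccccc4)cc(O)c3c2C)cc1OC`: 0.45 ug/mL in this assay

For compound 1 the value > 4 ug/mL is a limit of this assay and not a number; the evidence for it is only (the limit of > 4 ug/mL in this assay, at which 1 of the 3 values shown sits). Compound 1 therefore stands apart from compound 2 with 0.35 ug/mL and compound 3 with 0.45 ug/mL, both of which give numbers in this assay with only a small substituent on the benzoyl ring. Within the data shown here, no step between measured compounds differing in one place exists in this set.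

Compound 4 `Cc1c(C(=O)c2ccc(N(C)C)cc2)oc2cc(-c3ccccc3)cc(O)c12` differs from compound 1 by dimethylamino in place of phenoxy on an aromatic carbon. Among the measured compounds shown here, no measured step covers this change, so the direction in this assay is read off the set alone: compound 2 and compound 3 show that a smaller group on the benzoyl ring can come with a number rather than a limit, while compound 1 with the phenoxy group gives a limit.

The step from compound 1 to compound 4 is expected to go toward lower numbers, an at least 2.6-fold lower number from compound 1 to compound 4 (0.42 log units; beyond the scatter), though only a limit is known for compound 1. For compound 4 the estimate in this assay is 1.5 ug/mL, within 0.4 ug/mL to 6 ug/mL.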

Compound 4, half-maximal effective concentration: > 4 ug/mL
Compound 4 was reported as a limit (the forecaster's own chance of this, stated with the estimate: 30%); middle value at least 2.6-fold (0.42 log units) away from the limit.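

Compound 1 and compound 4 both stand only as a limit in this assay, so no step can be read between them: the limit of > 4 ug/mL in this assay, at which 2 of the 4 values shown sit.

The compounds shown leave open how far past this limit either compound lies, and whether dimethylamino in place of phenoxy on an aromatic carbon changes the read-out in this assay at all.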